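Stereo-undefined analogue of the chlorophenyl oxadiazoline

The compounds below may be only part of what the source reports. "The series", "measured", "known", "first", "only" and "open" are said of these compounds alone.

Of the compounds shown here, two have been measured in an assay on BTI cells for inhibition of Amine oxidase [flavin-containing] B (Homo sapiens), read by fluorescence and Amplex Red, with a stated time of 15 min; on this read-out lower numbers stand for stronger inhibition and higher numbers for weaker inhibition. Compound 1 `CC(=O)N1N=C(c2ccc([N+](=O)[O-])cc2)O[C@H]1c1ccc(Cl)c(Cl)c1` carries a nitro group on one aryl ring and in this assay compound 1 gives 523 nM. Compound 2 `CC(=O)N1N=C(c2ccc(Cl)cc2)O[C@@H]1c1ccc(Cl)c(Cl)c1` carries a chloro group in its place, and in this assay compound 2 gives 204 nM, the lowest of the two numbers; the step from compound 2 to compound 1 goes to a higher number and lies beyond the usual scatter.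

Compound 3 `CC(=O)N1N=C(c2ccc(Cl)cc2)OC1c1ccc(Cl)c(Cl)c1` is not yet measured. It differs from compound 2 as follows: the two compounds have the same atoms and bonds; at least one stereo element is drawn with a configuration in one of them and without one in the other: 1 of 1 stereo elements differ; a stereocentre at a saturated ring carbon is drawn R in compound 2 and without a configuration in compound 3. Among the measured compounds shown here, no measured pair shows the effect of leaving a configuration undrawn, so the size of the step in this assay is uncertain; a modest rise or no step beyond the scatter is expected. For compound 3 the expected value is 350 nM, with a range of 170 nM to 800 nM, which would mean an expected step of a 1.7-fold higher number from compound 2 to compound 3 (0.23 log units; within the scatter).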

Compound 3, half-maximal inhibitory concentration: 627 nM
Compound 3: the middle estimate sits 1.8-fold (0.25 log units) below what was measured, within the range that was stated.
By their numbers in this assay, from the lowest: compound 2; then compounds 1 and 3 (each within the scatter of the next).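

Configuration at the saturated ring carbon now has a measurable bearing on the series: with atoms and bonds unchanged, this assay shows a 3.1-fold higher number from compound 2 to compound 3 (0.49 log units; beyond the scatter). Compounds 1 and 2 could speak only to the nitro and chloro groups, whereas this pair isolates the drawing of a single stereocentre. The step can be tied to only one structural difference: the fact that one of compounds 2 and 3 is drawn with a defined configuration and the other without, at the place where they differ

Open, on these data alone, is how the opposite configuration alone would read, and whether the undrawn centre of compound 3 stands for a mixture or for a single unassigned form. Also open, as far as these compounds go, is how an amine or a methoxy group in place of the chloro group of compound 2 would read with its configuration kept.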